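The compounds below may be only part of what the source reports. "The series", "measured", "known", "first", "only" and "open" are said of these compounds alone.

Series notes. In a functional assay on MCF7 cells (Homo sapiens), tested at 2.5 uM (a higher number here means a weaker effect of the compound at the concentration tested, a lower number a stronger effect), compound 1 `CC(C)=CCOc1c(C)c(C)c2c(c1C)CCC(C)(COc1ccc(/C=C3\SC(=O)NC3=O)cc1C)O2` gives 89%, compound 2 `C=CCOc1c(C)c(C)c2c(c1C)CCC(C)(COc1ccc(/C=C3\SC(=O)NC3=O)cc1C)O2` gives 84% and compound 3 `COc1cc(/C=C2\SC(=O)NC2=O)ccc1OCC1(C)CCc2c(C)c(OCC=C(C)C)c(C)c(C)c2O1` gives 95%. Compound 2 holds the lowest of the three numbers, yet the step to compound 1, a number 5 percentage points lower from compound 1 to compound 2 (within the scatter), is within the scatter; only the gap to compound 3 lies beyond it. Compound 4 `C=CCOc1c(C)c(C)c2c(c1C)CCC(C)(COc1ccc(/C=C3\SC(=O)NC3=O)cc1Br)O2` differs from compound 2 in one place: bromo in place of methyl on an aromatic carbon. Among the compounds with values here, no measured step swaps a group on this aromatic carbon for bromo. The nearest comparison is the other ring-substituent swap, a number 6 percentage points higher from compound 1 to compound 3 (within the scatter), and the chain shortening, a number 5 percentage points lower from compound 1 to compound 2 (within the scatter), both within the scatter. A step no larger than the scatter is therefore expected, a number 1 percentage points higher from compound 2 to compound 4 (within the scatter). Compound 4 is estimated at 85% (range 70% to 98%).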

Compound 4, a percentage reported as activity, at one concentration (the size of the read-out at that concentration, not a potency): 102%
For compound 4 the middle estimate is 17 percentage points below the measured one; measured number outside the range, above it.
By their numbers in this assay, from the lowest: compounds 2, 1, 3 and 4 (each within the scatter of the next, the first and the last beyond it).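

On this aromatic carbon, ortho to a large group, bromo in place of methyl gives a step beyond the scatter in this assay (a number 18 percentage points higher from compound 2 to compound 4 (beyond the scatter)), toward a weaker effect at the concentration tested. The methoxy swap on this carbon stayed within the scatter (a number 6 percentage points higher from compound 1 to compound 3 (within the scatter)), so the position is not indifferent to every replacement of methyl. The data shown offer no measured explanation for the bromo step.

From the compounds shown here alone, whether chloro or a nitrile on this carbon would track with bromo or with methyl remains open. Also open, going by these compounds, is whether the bromo step holds with the 2-methylprop-1-en-1-yl group of compound 1.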